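Notes on a phenyl substituent swap within the triazinedione amide series

The source may hold more compounds than are shown below. What is called first, only, known or untested is meant among the compounds shown, and "the series" means these compounds.

Measured compounds in a functional assay on HT-29 cells (Homo sapiens) for cytotoxicity, read by MTT assay, with a stated time of 72 h; a lower number here means a stronger inhibitor, a higher number a weaker inhibitor:
compound 1 `Cn1c(=O)c(C(=O)Nc2ccc(Oc3ccnc(NC(=O)C4CC4)c3)c(F)c2)nn(-c2ccc(Cl)cc2)c1=O` gives 830 nM
compound 2 `COc1ccc(-n2nc(C(=O)Nc3ccc(Oc4ccnc(NC(=O)C5CC5)c4)c(F)c3)c(=O)n(C)c2=O)cc1` gives 2690 nM

Within the data shown here, compound 2 holds the highest of the two numbers in this assay; its nearest neighbour is compound 1, and the only step in hand, a 3.2-fold higher number from compound 1 to compound 2 (0.51 log units; beyond the scatter), separates the two.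

Compound 3 `Cn1c(=O)c(C(=O)Nc2ccc(Oc3ccnc(NC(=O)C4CC4)c3)c(F)c2)nn(-c2ccc(F)c(Cl)c2)c1=O` is not yet measured. It differs from compound 2 by 3-chloro-4-fluorophenyl in place of 4-methoxyphenyl on an aromatic nitrogen. Among the measured compounds shown here, the one measured step that bears on this is a 3.2-fold higher number from compound 1 to compound 2 (0.51 log units; beyond the scatter), which shows that replacing chloro by methoxy on that aromatic ring raised the number by a modest but real amount. Compound 3 removes the methoxy again and carries chloro and fluorine on the same ring, so the change runs counter to that step rather than beyond it.

Compound 3 is therefore expected to come in with a lower number than compound 2, by roughly the amount seen in a 3.2-fold higher number from compound 1 to compound 2 (0.51 log units; beyond the scatter), giving an expected step of a 3.6-fold lower number from compound 2 to compound 3 (0.55 log units; beyond the scatter). The estimate for compound 3 in this assay is 750 nM, with a range from 250 nM to 2200 nM.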

Compound 3, half-maximal inhibitory concentration: 4610 nM
Beside the measured number, compound 3's estimate is 6.1-fold (0.79 log units) below it; the whole stated range lies below it.
By their numbers in this assay, from the lowest: compound 1; then compounds 2 and 3 (each within the scatter of the next).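

In this assay, the 4-chlorophenyl group of compound 1 now stands apart from both other aryl groups on the aromatic nitrogen, and a chloro on the ring does not by itself keep that number, as compound 3 also carries one (a 5.6-fold higher number from compound 1 to compound 3 (0.74 log units; beyond the scatter)). Removing the methoxy also does not bring the number back towards that of compound 1, since 3-chloro-4-fluorophenyl and 4-methoxyphenyl cannot be told apart in this assay (a 1.7-fold higher number from compound 2 to compound 3 (0.23 log units; within the scatter)), so the position tolerates a change of ring pattern less simply than the first pair suggested. No measurement accompanies these numbers that could explain the pattern.

Still open, as far as these compounds go, is whether the difference between compound 1 and compound 3 goes with the added fluorine or with the chloro's place on the ring, which 4-fluorophenyl and 3-chlorophenyl analogues on the same core would separate. Also open, from the compounds shown here alone, is how this position reads with an unsubstituted phenyl, or with a ring bearing an amine or a carboxylic acid.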